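Catechol for methoxy on the hydrazone arm

A few compounds are considered here, and "the series" means these few. Any claim that something is new, unique, unknown or untested is made for them only; others in the source may bear on it.

Three members of the series have results in a functional assay on HepG2 cells (Homo sapiens) for inhibition, read by MTT assay, with a stated time of 48 h; on this read-out lower numbers stand for stronger inhibition and higher numbers for weaker inhibition. Compound 1 `O=[N+]([O-])c1cccc(CSc2nnc(-c3ccncc3)n2-c2ccccc2)c1` gives 22000 nM. Compound 2 `O=[N+]([O-])c1ccc(CSc2nnc(-c3ccncc3)n2-c2ccccc2)cc1` reaches only the limit of > 50000 nM in this assay, a limit rather than a number. Compound 3 `COc1ccc(/C=N/NC(=O)CSc2nnc(-c3ccncc3)n2-c2ccccc2)cc1` gives 27100 nM in this assay, the highest of the two numbers; its nearest neighbour is compound 1, and the gap lies within the usual scatter. Among the measured compounds shown here, the single measured step, an at least 2.2-fold higher number from compound 1 to compound 2 (0.35 log units; beyond the scatter), concerns the nitrophenyl arm and not the hydrazone part. Compound 4 `O=C(CSc1nnc(-c2ccncc2)n1-c1ccccc1)N/N=C/c1ccc(O)c(O)c1` differs from compound 3 by 3,4-dihydroxyphenyl in place of 4-methoxyphenyl on a carbon with a double bond to nitrogen. For the measured compounds named here, no measured step touches this position, so no step beyond the scatter is expected in this assay. Compound 4 is estimated at 25000 nM, between 10000 nM and 60000 nM. The expected step of a 1.1-fold lower number from compound 3 to compound 4 (0.04 log units; within the scatter) should stay within the scatter.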

Compound 4, half-maximal inhibitory concentration: 16900 nM
Compound 4: the middle estimate sits 1.5-fold (0.17 log units) above what was measured; low and high end bracket the measured number.
By their numbers in this assay, from the lowest: compounds 4, 1 and 3 (each within the scatter of the next). At a limit, above all of these: compound 2.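

Among the compounds shown here, at this position, on a carbon with a double bond to nitrogen, 3,4-dihydroxyphenyl in place of 4-methoxyphenyl gives a 1.6-fold lower number from compound 3 to compound 4 (0.21 log units; within the scatter) in this assay as the first measured step on the hydrazone arm. The exchange of the methoxy group for two hydroxyl groups, with hydrogen-bond donors entering where compound 3 has none, therefore leaves the number within the scatter. Nothing available offers a cause for this step.

Going by these compounds, whether an amine or a carboxylic acid on this phenyl ring would give a step beyond the scatter remains open. On these data alone, a single hydroxyl group at either ring position also remains open.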